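The source may hold more compounds than are shown below. What is called first, only, known or untested is meant among the compounds shown, and "the series" means these compounds.

Measured so far in an ADME assay on CCRF-CEM cells (Homo sapiens) for cytotoxicity, with a stated time of 4 days; a higher number here means that more compound is tolerated, a lower number that less compound is tolerated:
- compound 1 `CNC(=O)CCCCn1c(=O)c(C)cn([C@@H]2O[C@H](CO[Si](C)(C)C(C)(C)C)[C@@]3(OS(=O)(=O)C=C3N)[C@H]2O[Si](C)(C)C(C)(C)C)c1=O`: 10000 nM
- compound 2 `Cc1cn([C@@H]2O[C@H](CO[Si](C)(C)C(C)(C)C)[C@@]3(OS(=O)(=O)C=C3N)[C@H]2O[Si](C)(C)C(C)(C)C)c(=O)n(C(=O)CCCC(=O)N(C)C)c1=O`: 9500 nM

Compound 2, at 9500 nM, cannot be told apart from compound 1, as the two values lie within the usual scatter of each other. The next compound, compound 3 `CSC(=O)CCCC(=O)n1c(=O)c(C)cn([C@@H]2O[C@H](CO[Si](C)(C)C(C)(C)C)[C@@]3(OS(=O)(=O)C=C3N)[C@H]2O[Si](C)(C)C(C)(C)C)c1=O`, keeps the shared core and alters only the end of the chain: methylsulfanyl in place of dimethylamino on a carbonyl carbon. In short, methylsulfanyl stands in place of dimethylamino on a carbonyl carbon.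

Going by the values given here, the one measured step that bears on this is a 1.1-fold lower number from compound 1 to compound 2 (0.02 log units; within the scatter). It altered the same chain and stayed within the scatter. Among the compounds with values here, no measured compound carries methylsulfanyl, which makes this single step a weak guide. Even so, no clear shift is expected in this assay, and the expected step is a 1.1-fold lower number from compound 2 to compound 3 (0.05 log units; within the scatter). For compound 3, the estimated value is 8500 nM, with an expected range from 4000 nM to 15000 nM.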

Compound 3, half-maximal cytotoxic concentration: 9900 nM
Beside the measured number, compound 3's estimate is 1.2-fold (0.07 log units) below it; measured number inside the range.
By their numbers in this assay, from the lowest: compounds 2, 3 and 1 (each within the scatter of the next).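

In this assay the swap of dimethylamino for methylsulfanyl on a carbonyl carbon gives a 1.0-fold higher number from compound 2 to compound 3 (0.02 log units; within the scatter) and so shows that a sulfur-linked chain end reads the same here as the amide end of compound 2. The larger swap, (3-((methylsulfanyl)carbonyl)propyl)carbonyl in place of 4-(methylcarbamoyl)butyl on an aromatic nitrogen, gives a 1.0-fold lower number from compound 1 to compound 3 (0.00 log units; within the scatter) and places all three chains within the scatter of one another. No measured finding is available that would explain this closeness.

As far as these compounds go, whether a chain ending in a carboxylic acid or an amine, or a longer chain, would give a different number remains open. From the compounds shown here alone, the effect of changing the shared core also remains open, since all three compounds carry it unchanged.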